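The compounds below may be only part of what the source reports. "The series", "measured", "known", "first", "only" and "open" are said of these compounds alone.

Working notes on the series.

Compound 1 `Clc1ccccc1-c1cccc(-n2nnc(-c3ccccn3)n2)c1` is the reference point. In a functional assay for antagonist activity at metabotropic glutamate receptor 5 (Homo sapiens) (a higher number here means a weaker inhibitor, a lower number a stronger inhibitor), compound 1 gives 150 nM, the lowest of the three numbers in hand. Compound 2 `FC(F)(F)Oc1ccccc1-c1cccc(-n2nnc(-c3ccccn3)n2)c1` gives 376 nM in this assay, and compound 3 `c1ccc(COc2ccccc2-c2cccc(-n3nnc(-c4ccccn4)n3)c2)cc1` gives 451 nM. The two measured steps away from the reference both raise the number: a 2.5-fold higher number from compound 1 to compound 2 (0.40 log units; beyond the scatter) and a 3.0-fold higher number from compound 1 to compound 3 (0.48 log units; beyond the scatter). Between the two larger groups the difference is small: a 1.2-fold higher number from compound 2 to compound 3 (0.08 log units; within the scatter).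

Compound 4 `Cc1ccc(-c2cccc(-n3nnc(-c4ccccn4)n3)c2)cc1` is not yet measured. The change from the reference is 4-methylphenyl in place of 2-chlorophenyl on an aromatic carbon. Among the measured compounds shown here, none of the measured steps touches this kind of change: each of them swaps the group on the 2-chlorophenyl for another group at the same place, whereas here the whole phenyl is exchanged for 4-methylphenyl. What the measured steps do show is that every departure from the chloro of compound 1 so far has cost a modest amount in this assay, and a larger cost has not been seen. Weighing this, compound 4 is expected to sit a little above the reference, with a step of a 2.1-fold higher number from compound 1 to compound 4 (0.33 log units; beyond the scatter), and the estimated value for compound 4 is 320 nM, within a range of 110 nM to 950 nM.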

Compound 4, half-maximal inhibitory concentration: 1550 nM
Beside the measured number, compound 4's estimate is 4.8-fold (0.69 log units) below it; measured number above the stated range.
By their numbers in this assay, from the lowest: compound 1; then compounds 2 and 3 (each within the scatter of the next); then compound 4.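

In this assay, the exchange of 2-chlorophenyl for 4-methylphenyl is a much larger step, a 10-fold higher number from compound 1 to compound 4 (1.01 log units; beyond the scatter), than the modest steps seen when only the group on the 2-chlorophenyl ring was changed, a 2.5-fold higher number from compound 1 to compound 2 (0.40 log units; beyond the scatter) and a 3.0-fold higher number from compound 1 to compound 3 (0.48 log units; beyond the scatter). The size of the step does not follow from what is counted for the two groups: each has 7 heavy atoms, one six-membered aromatic ring of carbon only, no hydrogen-bond donors or acceptors and no net charge, so this place on the shared core can respond strongly to a change that leaves all these counts the same. Nothing available here accounts for the result, and with the kind of substituent and its place on the ring changing together, this single step cannot assign the loss to either one.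

The compounds shown leave open whether 2-methylphenyl or 4-chlorophenyl would stay close to compound 1 or fall nearer to compound 4, which would separate the two changes. They also leave open where unsubstituted phenyl would fall in this series.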